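Notes on a small cytotoxicity series, one compound pending

The compounds below may be only part of what the source reports. "The series", "measured", "known", "first", "only" and "open" are said of these compounds alone.

Measured so far:
- compound 1, `Clc1ccc(-c2nc(-c3c[nH]c4ccccc34)co2)cc1`: in a functional assay on LNCaP cells (Homo sapiens) for cytotoxicity, read by MTT assay, with a stated time of 48 h (a higher number here means a weaker inhibitor, a lower number a stronger inhibitor), compound 1 gives 505000 nM
- compound 2, `c1ccc2c(-c3coc(C4CCNCC4)n3)c[nH]c2c1`: in this assay compound 2 gives 476000 nM
- compound 3, `Cn1cc(-c2coc(C3CCNCC3)n2)c2ccccc21`: in this assay compound 3 gives 400000 nM

All three numbers lie within the scatter of one another, so no order among them is claimed. Two single-point changes connect them. From compound 2 to compound 1 the change is 4-chlorophenyl in place of piperidin-4-yl on an aromatic carbon, and the step is a 1.1-fold higher number from compound 2 to compound 1 (0.03 log units; within the scatter). From compound 2 to compound 3 the change is methyl in place of hydrogen on an aromatic nitrogen, and the step is a 1.2-fold lower number from compound 2 to compound 3 (0.08 log units; within the scatter).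

The unmeasured compound 4, `Cn1cc(-c2coc(-c3ccc(Cl)cc3)n2)c2ccccc21`, differs from compound 3 by 4-chlorophenyl in place of piperidin-4-yl on an aromatic carbon. Among the compounds with values here, this is the same kind of change as the one from compound 2 to compound 1; the cores differ by methyl in place of hydrogen on an aromatic nitrogen, and the surroundings of the place are described differently, as two ring bonds from the ring atom that bears a large group in one case and two ring bonds from the ring atom that bears a group of 9 heavy atoms in the other.

Within the data shown here, for compound 4 in this assay the expected step is a 1.1-fold higher number from compound 3 to compound 4 (0.03 log units; within the scatter), set beside a 1.1-fold higher number from compound 2 to compound 1 (0.03 log units; within the scatter), which is the only measured instance of this kind of change and which stayed within the scatter. The estimate for compound 4 in this assay is therefore 430000 nM, expected to fall between 200000 nM and 900000 nM.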

Compound 4, half-maximal inhibitory concentration: 378000 nM
The estimate for compound 4 lay 1.1-fold (0.06 log units) above the measured number; measured number inside the range.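

In this assay, 4-chlorophenyl in place of piperidin-4-yl on an aromatic carbon gives a 1.1-fold lower number from compound 3 to compound 4 (0.02 log units; within the scatter), and the two instances of this change agree: the same change on two cores in this assay, a 1.1-fold higher number (0.03 log units; within the scatter) from compound 2 to compound 1 and a 1.1-fold lower number (0.02 log units; within the scatter) from compound 3 to compound 4, 1.1-fold (0.05 log units) apart, within the scatter of two such steps. Methyl in place of hydrogen on an aromatic nitrogen, now read on the cores bearing 4-chlorophenyl, gives a 1.3-fold lower number from compound 1 to compound 4 (0.13 log units; within the scatter), and this change also agrees with its earlier instance: the same change on two cores in this assay, a 1.2-fold lower number (0.08 log units; within the scatter) from compound 2 to compound 3 and a 1.3-fold lower number (0.13 log units; within the scatter) from compound 1 to compound 4, 1.1-fold (0.05 log units) apart, within the scatter of two such steps. Within the data shown here, in this series, then, neither change moves the number beyond the scatter on either core, but that agreement rests on steps that are all within the scatter, so it does not show that a change with a larger step would carry from one core to another, and it gives no order among the compounds.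

The compounds shown carry only piperidin-4-yl or 4-chlorophenyl on the five-membered aromatic ring with 1 nitrogen and 1 oxygen, and only hydrogen or methyl on the aromatic nitrogen. As far as these compounds go, whether an open-chain amine or a carboxylic acid on that ring, or a longer alkyl chain on that nitrogen, would give a step beyond the scatter remains open.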